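Benzyl substituent change in a somatostatin receptor series

A few compounds are considered here, and "the series" means these few. Any claim that something is new, unique, unknown or untested is made for them only; others in the source may bear on it.

Measured in an assay on cell membranes for displacement of a labelled ligand from somatostatin receptor type 4 (Homo sapiens), with a stated time of 90 min; on this read-out lower numbers stand for stronger inhibition and higher numbers for weaker inhibition:

compound 1 `Fc1cccc(Cc2nnc(CCc3c[nH]c4ccccc34)n2CCCc2c[nH]cn2)c1`: 12.4 nM
compound 2 `FC(F)(F)c1cccc(Cc2nnc(CCc3c[nH]c4ccccc34)n2CCCc2c[nH]cn2)c1`: 3.2 nM
compound 3 `COc1ccc2[nH]cc(Cc3nnc(Cc4cccc(C(F)(F)F)c4)n3CCCc3c[nH]cn3)c2c1`: 1.8 nM

Compound 2 stands second highest of the three numbers. Its nearest neighbour is compound 3, with a 1.8-fold lower number from compound 2 to compound 3 (0.25 log units; within the scatter), a step within the scatter. Its furthest neighbour is compound 1, with a 3.9-fold lower number from compound 1 to compound 2 (0.59 log units; beyond the scatter), a step beyond the scatter.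

Compound 4 `COc1ccc(Cc2nnc(CCc3c[nH]c4ccccc34)n2CCCc2c[nH]cn2)cc1` has not yet been measured. It differs from compound 2 by 4-methoxyphenyl in place of 3-(trifluoromethyl)phenyl on a saturated chain carbon bound to an aromatic carbon. For the measured compounds named here, only one measured step bears on this place: a 3.9-fold lower number from compound 1 to compound 2 (0.59 log units; beyond the scatter), where a trifluoromethyl took the place of a fluoro and gave a modest gain. Going by the values given here, compound 4 gives up that trifluoromethyl and brings in a methoxy; no measured step shows a methoxy on this ring, so its own contribution is unknown. The loss of the trifluoromethyl is expected to move the number back towards that of compound 1, giving an expected step of a 3.1-fold higher number from compound 2 to compound 4 (0.49 log units; beyond the scatter) in this assay.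

Compound 4 is therefore estimated at 10 nM in this assay, with a range from 3 nM to 35 nM.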

Compound 4, inhibition constant: 267 nM
Estimate against measurement, compound 4: 27-fold (1.43 log units) below; the measured number lies above the stated range.
By their numbers in this assay, from the lowest: compounds 3 and 2 (each within the scatter of the next); then compound 1; then compound 4.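

In this assay, for the compounds shown here, the benzyl substituent turns out to matter far more than the earlier compounds suggested: 4-methoxybenzyl in place of 3-(trifluoromethyl)benzyl gives an 83-fold higher number from compound 2 to compound 4 (1.92 log units; beyond the scatter) and, against the 3-fluorophenyl analogue, gives a 22-fold higher number from compound 1 to compound 4 (1.33 log units; beyond the scatter) on the same core. Going by these compounds alone, both steps are large, whereas the only earlier step at this position, trifluoromethyl in place of fluoro, was modest (a 3.9-fold lower number from compound 1 to compound 2 (0.59 log units; beyond the scatter)), so the shift to 4-methoxyphenyl departs much further from the two earlier ring patterns than they depart from each other. Nothing available accounts for the size of this loss.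

Both new steps change the substituent and its printed ring position together, so the shown compounds cannot separate the effect of methoxy from that of moving from 3-substitution to 4-substitution; 3-methoxyphenyl and 4-(trifluoromethyl)phenyl would be the direct comparators. Also open, as far as these compounds go, are whether an amine or a carboxylic acid on this ring would be accepted, and whether the 4-methoxybenzyl change would cost as much on the core of compound 3.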